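Swapping tert-butyl for pyrrolidin-1-yl in compound 2

The source may report more compounds than this note shows. Statements on the series, on what has been measured and on what is new or still open speak of the compounds shown alone.

Among the measured compounds shown here, in a toxicity assay on microsomes from liver (Homo sapiens) for metabolic stability, read by LC-MS, using NADPH, tested at 1 uM (a higher number here means faster removal of the compound, a lower number slower removal), compound 2 (`Cc1nc(C)n(CC(=O)N2CCN(c3sc(C(F)(F)F)nc3-c3cnc(C(C)(C)C)nc3)C[C@H]2C)n1`) gives 449 mL.min-1.g-1 as the only true number on hand. Compound 1 (`Cc1nc(C)n(CC(=O)N2CCN(c3sc(C(F)(F)F)nc3-c3cnc(C4CC4)nc3)C[C@H]2C)n1`) gives < 10 mL.min-1.g-1 as a limit of the assay. For the measured compounds named here, the one measured step (an at least 44-fold higher number from compound 1 to compound 2 (1.65 log units; beyond the scatter)) is large and beyond the scatter, with tert-butyl in place of cyclopropyl. Compound 3 (`Cc1nc(C)n(CC(=O)N2CCN(c3sc(C(F)(F)F)nc3-c3cnc(N4CCCC4)nc3)C[C@H]2C)n1`) instead carries pyrrolidin-1-yl in place of tert-butyl on an aromatic carbon. Going by the values given here, no measured step covers this group, yet compound 2 stands high at 449 mL.min-1.g-1 and so a clear fall is expected in this assay, smaller than that measured step. The expected change (a 5.6-fold lower number from compound 2 to compound 3 (0.75 log units; beyond the scatter)) is only an estimate. Compound 3 is estimated at 80 mL.min-1.g-1 (expected range 15 mL.min-1.g-1 to 350 mL.min-1.g-1)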

Compound 3, intrinsic clearance in microsomes: 338 mL.min-1.g-1
Compound 3: middle estimate off by 4.2-fold (0.63 log units), on the low side, and the stated range covers the measured number.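

In this assay, placing pyrrolidin-1-yl instead of tert-butyl on the carbon between two ring nitrogen atoms gives a 1.3-fold lower number from compound 2 to compound 3 (0.12 log units; within the scatter), so these two groups cannot be told apart here. A ring at this position is therefore not enough to match cyclopropyl, since pyrrolidin-1-yl also carries one and the comparison gives an at least 33-fold higher number from compound 1 to compound 3 (1.52 log units; beyond the scatter). That step rests on a limit, not a true number: the limit of < 10 mL.min-1.g-1 in this assay, at which 1 of the 3 values shown sits.

As far as these compounds go, whether a morpholin-4-yl ring or a dimethylamino group at this position would stay with compound 2 and compound 3 or fall towards compound 1 remains open.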